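This account rests on a few compounds, and the source may have more. Where it says the series, first, only, none or still open, it means among the compounds named here.

Measured in a functional assay on HT-1080 cells (Homo sapiens) for cytotoxicity, read by MTT assay, with a stated time of 72 h; a higher number here means a weaker inhibitor, a lower number a stronger inhibitor:

compound 1 `COc1ccc(/C=C2\CCC/C(=C\c3cccc(Cl)c3)C2=O)cc1OC`: 4900 nM
compound 2 `COc1ccc(/C=C2\CCC/C(=C\c3ccc(Br)cc3)C2=O)cc1OC`: 4300 nM
compound 3 `COc1cccc(/C=C2\CCC/C(=C\c3ccc(OC)c(OC)c3)C2=O)c1`: 4600 nM

These three values lie within the usual scatter of one another. Compound 3 therefore stands level with the other two, and no ranking can be read from the numbers.

The next compound, compound 4 `COc1ccc(/C=C2\CCC/C(=C\c3ccc(O)cc3)C2=O)cc1OC`, has not yet been measured. It differs from compound 3 by a single change, 4-hydroxyphenyl in place of 3-methoxyphenyl, on a double-bonded chain carbon bound to a double-bonded ring carbon: 4-hydroxyphenyl in place of 3-methoxyphenyl on a double-bonded chain carbon bound to a double-bonded ring carbon.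

All three measured steps involve this same place. They are a 1.1-fold lower number from compound 1 to compound 2 (0.06 log units; within the scatter), a 1.1-fold lower number from compound 1 to compound 3 (0.03 log units; within the scatter) and a 1.1-fold higher number from compound 2 to compound 3 (0.03 log units; within the scatter). Each stays within the scatter, which means that swapping these groups has not yet moved the number measurably. Among the measured compounds shown here, no measured compound carries a 4-hydroxyphenyl group, and the new hydrogen-bond donor is untested in this set. With a 1.1-fold higher number from compound 2 to compound 3 (0.03 log units; within the scatter) as the closest guide, no step beyond the scatter is expected in this assay, though the uncertainty is wide in both directions. The estimated step is a 1.2-fold lower number from compound 3 to compound 4 (0.08 log units; within the scatter). The expected value for compound 4 is 3800 nM, with an estimated range from 1500 nM to 8000 nM.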

Compound 4, half-maximal inhibitory concentration: 16800 nM
Estimate against measurement, compound 4: 4.4-fold (0.65 log units) below; the whole stated range lies below it.
By their numbers in this assay, from the lowest: compounds 2, 3 and 1 (each within the scatter of the next); then compound 4.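

In this assay, this position no longer looks indifferent to what it carries, and compound 4 is the weakest of the set. The 4-hydroxyphenyl group gives a 3.7-fold higher number from compound 3 to compound 4 (0.56 log units; beyond the scatter) when it replaces 3-methoxyphenyl, a 3.4-fold higher number from compound 1 to compound 4 (0.54 log units; beyond the scatter) when it replaces 3-chlorophenyl, and a 3.9-fold higher number from compound 2 to compound 4 (0.59 log units; beyond the scatter) when hydroxy replaces bromo on the aromatic carbon. The earlier swaps among compounds 1, 2 and 3 had all stayed within the scatter, so the position accepts some changes without a measurable shift but not this one, and nothing here gives a measured reason for the loss.

From the compounds shown here alone, the step from compound 2 changes only the bromo group to hydroxy, while the step from compound 3 also swaps 3-methoxyphenyl as a whole, so it remains open how much depends on the hydroxy group itself and how much on the loss of the groups it replaces. An amine or a carboxylic acid in place of the hydroxy would show whether the higher number belongs to hydroxy alone or extends to other groups at this place.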